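Series notes: two measurements at the limit, a third pending

The source may hold more compounds than are shown below. What is called first, only, known or untested is meant among the compounds shown, and "the series" means these compounds.

Measured compounds:
compound 1 `COc1ccc(/C=C/C(=O)c2ccc(OC)c3c2OC(C)(C)C=C3)c(F)c1` — > 10000 nM
compound 2 `COc1ccc(C(=O)/C=C/c2ccc(N(c3ccccc3)c3ccccc3)cc2)c2c1C=CC(C)(C)O2` — > 10000 nM

In a functional assay on HCT-116 cells (Homo sapiens) for antiproliferative activity, read by MTT assay, with a stated time of 24 h (a lower number here means a stronger inhibitor, a higher number a weaker inhibitor), compound 1 gives > 10000 nM, which is a limit of the assay and not a number. Compound 2 likewise gives > 10000 nM in this assay, again a limit rather than a number. Going by the values given here, compound 1 therefore stands at the limit of > 10000 nM in this assay, at which 2 of the 2 values shown sit; nothing in the numbers so far separates it from compound 2, and no step between measured compounds can be sized.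

Compound 3 `COc1ccc(C(=O)/C=C/c2ccco2)c2c1C=CC(C)(C)O2` is not yet measured. It differs from compound 1 as follows: furan-2-yl in place of 2-fluoro-4-methoxyphenyl on a double-bonded chain carbon bound to a double-bonded chain carbon. The shared core and the double-bonded chain are kept; only the aryl part on the chain carbon is exchanged.

Among the compounds with values here, with both measured values sitting at the limit, no direction for the step in this assay can be read from the data. The expectation is that compound 3 also reaches no reportable number, so the estimated step that the limit leaves unreadable from compound 1 to compound 3 is none beyond the scatter. Compound 3 is expected at 15000 nM in this assay, with a range of 4000 nM to 60000 nM.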

Compound 3, half-maximal inhibitory concentration: > 10000 nM
Compound 3 gave a limit, no number; the forecaster's own chance of this, stated with the estimate: 70%; the middle value is on the limit's open side.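

No step from compound 1 to compound 3 can be read, since compound 3, like compound 1, gives only a limit and not a number: the limit of > 10000 nM in this assay, at which 3 of the 3 values shown sit.

The compounds shown leave open whether any aryl part on the chain carbon gives a readable value in this assay, and how compound 1, compound 2 and compound 3 rank against each other.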